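A few compounds are considered here, and "the series" means these few. Any claim that something is new, unique, unknown or untested is made for them only; others in the source may bear on it.

For the measured compounds named here, compound 2 `COc1cc(-c2nn(-c3cccc(NC(=O)Nc4cc(C(F)(F)F)cc(C(F)(F)F)c4)c3)cc2-c2ccncc2)ccc1Cl` gives 1710 nM in a functional assay on SF-539 cells (Homo sapiens) for inhibition, read by sulforhodamine B assay, with a stated time of 48 h (on this read-out higher numbers stand for weaker inhibition of growth and lower numbers for stronger inhibition of growth), and stands at the low end of the three numbers so far; its gap to compound 3 is within the scatter, its gap to compound 1 beyond it. Compound 3 `COc1cc(-c2nn(-c3cccc(NC(=O)Nc4cccc(C(F)(F)F)c4)c3)cc2-c2ccncc2)ccc1Cl` gives 2420 nM in this assay, and a 1.4-fold higher number from compound 2 to compound 3 (0.15 log units; within the scatter). Compound 1 `O=C(Nc1cccc(-n2cc(-c3ccncc3)c(-c3ccc(Cl)c(O)c3)n2)c1)Nc1cccc(C(F)(F)F)c1` gives 11600 nM in this assay. The change to compound 4 `O=C(Nc1cccc(-n2cc(-c3ccncc3)c(-c3ccc(Cl)c(O)c3)n2)c1)Nc1cc(C(F)(F)F)cc(C(F)(F)F)c1` is hydrogen in place of methyl on an oxygen on an aromatic ring, methoxy to hydroxy on the 4-chloro-3-methoxyphenyl group. The same change in the opposite direction has been measured: a 4.8-fold lower number from compound 1 to compound 3 (0.68 log units; beyond the scatter). Undoing the methyl from compound 2 is therefore expected to raise the number by a comparable amount, well beyond the scatter. For compound 4 the estimate in this assay is 8200 nM, range 3500 nM to 19000 nM. The expected step is a 4.8-fold higher number from compound 2 to compound 4 (0.68 log units; beyond the scatter).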

Compound 4, concentration for total growth inhibition: 1490 nM
The estimate for compound 4 lay 5.5-fold (0.74 log units) above the measured number, and the stated range ends above it.
By their numbers in this assay, from the lowest: compounds 4, 2 and 3 (each within the scatter of the next); then compound 1.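

In this assay, methoxy to hydroxy on the 4-chloro-3-methoxyphenyl group has no fixed effect. With the added trifluoromethyl, the change gives a 1.1-fold lower number from compound 2 to compound 4 (0.06 log units; within the scatter). The larger step without the added trifluoromethyl does not carry over to this core: the same change on two cores in this assay, a 4.8-fold lower number (0.68 log units; beyond the scatter) from compound 1 to compound 3 and a 1.1-fold higher number (0.06 log units; within the scatter) from compound 4 to compound 2, 5.5-fold (0.74 log units) apart, beyond the scatter of two such steps. Trifluoromethyl in place of hydrogen on an aromatic carbon likewise depends on the partner group, with a 7.8-fold lower number from compound 1 to compound 4 (0.89 log units; beyond the scatter) in the hydroxy pair, far from the step within the scatter in the methoxy pair: the same change on two cores in this assay, a 1.4-fold higher number (0.15 log units; within the scatter) from compound 2 to compound 3 and a 7.8-fold higher number (0.89 log units; beyond the scatter) from compound 4 to compound 1, 5.5-fold (0.74 log units) apart, beyond the scatter of two such steps. The two changes therefore do not act independently across these four compounds.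

Going by these compounds, whether an ethoxy group or an amine in place of the hydroxy would follow the same dependence remains open.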